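This account rests on a few compounds, and the source may have more. Where it says the series, first, only, none or still open, it means among the compounds named here.

Measured in a functional assay on HeLa cells (Homo sapiens) for cytotoxicity, read by sulforhodamine B assay, with a stated time of 72 h; a lower number here means a stronger inhibitor, a higher number a weaker inhibitor:
- compound 1 `C=C1C(=O)O[C@@H]2CC(C)=C([C@@H](C)CCCOC(C)=O)[C@@H](OC(=O)COc3cccc(C(C)=O)c3)[C@H]12`: 38600 nM
- compound 2 `C=C1C(=O)O[C@@H]2CC(C)=C([C@@H](C)CCCOC(C)=O)[C@@H](OC(=O)COc3ccc(C(C)=O)cc3)[C@H]12`: 43900 nM
- compound 3 `C=C1C(=O)O[C@@H]2CC(C)=C([C@@H](C)CCCOC(C)=O)[C@@H](OC(=O)COc3cccc4cccnc34)[C@H]12`: 8940 nM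

Compound 1 and compound 2 lie within the scatter of each other, a 1.1-fold higher number from compound 1 to compound 2 (0.06 log units; within the scatter), and compound 3 has the lowest number of the three. Seen from compound 1, quinolin-8-yl in place of 3-acetylphenyl gives a 4.3-fold lower number from compound 1 to compound 3 (0.64 log units; beyond the scatter). Seen from compound 2, quinolin-8-yl in place of 4-acetylphenyl gives a 4.9-fold lower number from compound 2 to compound 3 (0.69 log units; beyond the scatter).

The next step leads to compound 4 `C=C1C(=O)O[C@@H]2CC(C)=C([C@@H](C)CCCOC(C)=O)[C@@H](OC(=O)c3ccc(F)cc3)[C@H]12`, not yet measured: 4-fluorophenyl in place of (3-acetylphenoxy)methyl on a carbonyl carbon. In words, 4-fluorophenyl stands in place of (3-acetylphenoxy)methyl on a carbonyl carbon. Each measured step exchanges only the group on an oxygen on a saturated carbon, so none of them covers this change directly. They show only how far the numbers have moved so far, from no change beyond the scatter to a modest one. The data hold no direct comparison for the larger exchange, so the direction is weakly founded, with a slight lean to a lower number resting on compound 3 at 8940 nM. The expected change stays small and uncertain: a 1.8-fold lower number from compound 1 to compound 4 (0.24 log units; within the scatter). In this assay the estimate for compound 4 is 22000 nM, with an expected range from 7000 nM to 60000 nM.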

Compound 4, half-maximal inhibitory concentration: 12000 nM
Compound 4: middle estimate off by 1.8-fold (0.26 log units), on the high side, and the stated range covers the measured number.
By their numbers in this assay, from the lowest: compounds 3 and 4 (each within the scatter of the next); then compounds 1 and 2 (each within the scatter of the next).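

In this assay, 4-fluorophenyl on the carbonyl carbon gives a 3.2-fold lower number from compound 1 to compound 4 (0.51 log units; beyond the scatter) and, in place of (4-acetylphenoxy)methyl, a 3.7-fold lower number from compound 2 to compound 4 (0.56 log units; beyond the scatter), so at this position the lower number does not depend on keeping an aryloxymethyl group or on the quinolin-8-yl group of compound 3. The step to the quinoline ester is a 1.3-fold higher number from compound 3 to compound 4 (0.13 log units; within the scatter), which places a group of 7 heavy atoms with 0 hydrogen-bond acceptors level with compound 3, while the acetyl-bearing groups that leave have 11 heavy atoms and 2 hydrogen-bond acceptors. No measurement on hand explains these steps.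

The compounds shown leave open whether the fluorine of compound 4 contributes at all, a question that plain phenyl or 4-chlorophenyl on the same carbonyl carbon would address. Also open, as far as these compounds go, is how non-aromatic or charged groups behave at this position, such as a longer alkyl chain, a dimethylaminomethyl group or a carboxylic acid on the phenyl ring.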